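Swapping the Aryl Group on a Shared Core

The compounds below may be only part of what the source reports. "The series", "measured", "known", "first", "only" and "open" are said of these compounds alone.

Three measured compounds share one core and differ only in the aryl group sitting on a carbon with a double bond to nitrogen. Compound 1 `Cn1c(=O)c(=O)n(C2CCCC2)c2nc(N/N=C/c3ccc(C(F)(F)F)cc3)ncc21` carries 4-(trifluoromethyl)phenyl there, compound 2 `Cn1c(=O)c(=O)n(C2CCCC2)c2nc(N/N=C/c3cccs3)ncc21` carries thiophen-2-yl, and compound 3 `Cn1c(=O)c(=O)n(C2CCCC2)c2nc(N/N=C/c3ccc(F)cc3Br)ncc21` carries 2-bromo-4-fluorophenyl. In a functional assay on PC-3 cells (Homo sapiens) for antiproliferative activity, read by MTT assay (on this read-out higher numbers stand for weaker inhibition and lower numbers for stronger inhibition), compound 1 gives 23600 nM, compound 2 gives 75600 nM and compound 3 gives 9250 nM. Compound 1 therefore stands at the second highest of the three numbers: there is a 3.2-fold higher number from compound 1 to compound 2 (0.51 log units; beyond the scatter), while there is a 2.6-fold lower number from compound 1 to compound 3 (0.41 log units; beyond the scatter), and the widest gap is an 8.2-fold lower number from compound 2 to compound 3 (0.91 log units; beyond the scatter).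

Compound 4 `Cn1c(=O)c(=O)n(C2CCCC2)c2nc(N/N=C/c3ccccc3Cl)ncc21` is the next variation on this core: 2-chlorophenyl in place of 4-(trifluoromethyl)phenyl on a carbon with a double bond to nitrogen. The step that bears most directly on it is a 2.6-fold lower number from compound 1 to compound 3 (0.41 log units; beyond the scatter), because compound 3, like compound 4, replaces the trifluoromethyl-bearing ring with a halogen-bearing phenyl, and that replacement gave a modest lowering. Within the data shown here, with only one such comparison, a similar modest lowering is expected rather than a large one. The expected step is a 2.0-fold lower number from compound 1 to compound 4 (0.29 log units; within the scatter). Compound 4 is estimated at 12000 nM, within a range from 5000 nM to 30000 nM.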

Compound 4, half-maximal inhibitory concentration: 16300 nM
Compound 4: the middle estimate sits 1.4-fold (0.13 log units) below what was measured; measured number inside the range.
By their numbers in this assay, from the lowest: compounds 3, 4 and 1 (each within the scatter of the next, the first and the last beyond it); then compound 2.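

The 2-chlorophenyl group gives a result that cannot be separated from those of its two nearest neighbours in this assay: a 1.4-fold lower number from compound 1 to compound 4 (0.16 log units; within the scatter) and a 1.8-fold higher number from compound 3 to compound 4 (0.25 log units; within the scatter) both stay within the usual scatter of repeated measurements, even though the two groups compared with it, 4-(trifluoromethyl)phenyl and 2-bromo-4-fluorophenyl, differ from each other by more than that scatter. Among these compounds, the clear difference lies elsewhere, in a 4.6-fold lower number from compound 2 to compound 4 (0.67 log units; beyond the scatter), which is beyond the scatter and makes this the third substituted phenyl group to give a lower number than thiophen-2-yl, with no compound among the four going against that pattern. Nothing measured here explains why the thiophen-2-yl compound stands apart from the others.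

As far as these compounds go, a plain phenyl group at this place would show what the chlorine of compound 4 adds on its own, and that comparison remains open. From the compounds shown here alone, it is also open whether a ring carrying an amine or a carboxylic acid on a carbon with a double bond to nitrogen would fall with the substituted phenyl groups, with thiophen-2-yl, or outside both.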